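The compounds below may be only part of what the source reports. "The series", "measured", "known", "first", "only" and "open" are said of these compounds alone.

Measured so far:
compound 1 `COc1ccc(F)cc1CNCCCNc1ccnc2cc(Oc3ccc(F)cc3)ccc12` — 6600 nM
compound 2 `Fc1ccc(Oc2ccc3c(NCCCNCc4ccco4)ccnc3c2)cc1` — 16000 nM

Compound 2 carries the highest of the two numbers in an ADME assay on HepG2 cells (Homo sapiens) for cytotoxicity, read by luminescence, CellTiter-Glo and ATP content, with a stated time of 72 h; a lower number here means that less compound is needed, a higher number that more compound is needed for the effect; its nearest neighbour is compound 1, and the step between them is a 2.4-fold higher number from compound 1 to compound 2 (0.38 log units; beyond the scatter). That step changes the group on the saturated chain carbon bound to an amine nitrogen and tells nothing about the other end of the molecule.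

Compound 3 `Clc1ccc(Oc2ccc3c(NCCCNCc4ccco4)ccnc3c2)cc1` differs from compound 2 by chloro in place of fluoro on an aromatic carbon. For the measured compounds named here, no measured step touches that ring position, so the only anchor is the value of compound 2 itself. Going by the values given here, the expectation for compound 3 in this assay is therefore a step of no change at the digits printed from compound 2 to compound 3 (within the scatter), nothing beyond the scatter, with a wide range because no precedent for this change is available. Compound 3 is estimated at 16000 nM, between 7000 nM and 36000 nM.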

Compound 3, half-maximal effective concentration: 7800 nM
Compound 3: the middle estimate sits 2.1-fold (0.31 log units) above what was measured; the measured number falls inside the stated range.
By their numbers in this assay, from the lowest: compounds 1 and 3 (each within the scatter of the next); then compound 2.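

For the compounds shown here, at this end of the molecule, the 4-fluorophenoxy to 4-chlorophenoxy change gives the first readable step in this assay: a 2.1-fold lower number from compound 2 to compound 3 (0.31 log units; beyond the scatter). The position is therefore not silent here: exchanging one halogen atom on the aromatic carbon para to a large group moves the number beyond the scatter, with no change in the counted hydrogen-bond donors, hydrogen-bond acceptors or net charge. No measurement at hand bears on the origin of this step.

The compounds shown leave open whether the same exchange gives a similar step with 5-fluoro-2-methoxyphenyl in place of furan-2-yl at the other end. They also leave open how bromo, methyl or plain hydrogen at this ring position would compare with fluoro and chloro.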